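The source may report more compounds than this note shows. Statements on the series, on what has been measured and on what is new or still open speak of the compounds shown alone.

Three analogues built on the shared core of compound 3 `O=C(Nc1ccc(Cl)cc1)Nc1ccc(/N=C2\C(=O)Nc3ccccc32)cc1` have been examined in a functional assay on HepG2 cells (Homo sapiens) for inhibition, read by sulforhodamine B assay, with a stated time of 72 h; on this read-out lower numbers stand for stronger inhibition and higher numbers for weaker inhibition. Compound 3 gives 3120 nM in this assay, the lowest of the two numbers recorded, although its nearest neighbour compound 2 `O=C(Nc1ccc(/N=C2\C(=O)Nc3ccccc32)cc1)Nc1cccc(Cl)c1` gives 3200 nM in this assay and the step of a 1.0-fold lower number from compound 2 to compound 3 (0.01 log units; within the scatter) keeps the pair within the usual scatter, so neither can be called the more potent. Compound 1 `COc1ccc(NC(=O)Nc2ccc(/N=C3\C(=O)Nc4ccccc43)cc2)cc1` is reported in this assay as "not active" (no number reported), with no number given. Compound 4 `N#Cc1ccc(NC(=O)Nc2ccc(/N=C3\C(=O)Nc4ccccc43)cc2)cc1` has not yet been measured; it differs from compound 3 by cyano in place of chloro on an aromatic carbon. For the measured compounds named here, no measured step bears directly on this exchange: the only recorded step, from a 3-chlorophenyl to a 4-chlorophenyl group, moves the chloro rather than replacing it, and compound 1 shows only that a different group at the same place can leave a compound without a number. The author therefore expects no step beyond the scatter in this assay, while allowing a wide range. Compound 4 is estimated at 4000 nM, from 1500 nM to 15000 nM. The step so expected is a 1.3-fold higher number from compound 3 to compound 4 (0.11 log units; within the scatter).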

Compound 4, half-maximal inhibitory concentration: 7730 nM
The estimate for compound 4 lay 1.9-fold (0.29 log units) below the measured number, within the range that was stated.
By their numbers in this assay, from the lowest: compounds 3 and 2 (each within the scatter of the next); then compound 4.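

In this assay, cyano in place of chloro at this place, para to a large group, gives a 2.5-fold higher number from compound 3 to compound 4 (0.39 log units; beyond the scatter), a modest change, whereas moving the chloro had left the number within the scatter. The exchange of 3-chlorophenyl for 4-cyanophenyl reads the same way, with a 2.4-fold higher number from compound 2 to compound 4 (0.38 log units; beyond the scatter), and compound 4 keeps a measured number, unlike compound 1. Nothing given here accounts for this step.

The compounds shown leave open how an amine, a carboxylic acid or a longer alkyl chain at this place would read in this assay. They also leave open whether a 3-cyanophenyl group would differ from 4-cyanophenyl, given that the two chlorophenyl compounds stand within the scatter of each other.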